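The compounds below may be only part of what the source reports. "The series", "measured", "known", "first", "only" and "open" are said of these compounds alone.

Compound 1 `CCCCCCCCNC(=O)CCCSC[C@H](NC(=O)OCc1ccccc1)C(=O)Nc1ccccc1`: "not active" (no number reported) in an assay for inhibition of NAD-dependent protein deacylase sirtuin-6 (Homo sapiens), read by HPLC, with stated times of 15 min and 1 h, tested at 333 uM; on this read-out lower numbers stand for less inhibition and higher numbers for more inhibition at the one concentration tested (going by the name of the read-out). Compound 2 `O=C(O)CCNC(=O)CCCSC[C@H](NC(=O)OCc1ccccc1)C(=O)Nc1ccccc1`: 43% in this assay.

In this assay compound 1 gives "not active" (no number reported), so no single number places it on the scale; it stands below compound 2, which gives 43%. Compound 3 `O=C(O)CNC(=O)CCCSC[C@H](NC(=O)OCc1ccccc1)C(=O)Nc1ccccc1` differs from compound 1 by carboxy in place of heptyl on a saturated chain carbon bound to an amide-type nitrogen. For the measured compounds named here, no measured step runs along this path, yet the change is expected to raise inhibition beyond the usual scatter, because compound 2 gives 43% in this assay. Compound 3 is therefore estimated at 40%, within a range from 15% to 65%.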

Compound 3, a percentage reported as inhibition, at one concentration (the size of the read-out at that concentration, not a potency): 53%
The estimate for compound 3 lay 13 percentage points below the measured number; the measured number falls inside the stated range.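

Putting carboxy in place of carboxymethyl on a saturated chain carbon bound to an amide-type nitrogen gives a number 10 percentage points higher from compound 2 to compound 3 (within the scatter) in this assay. The two carboxy-ended chains therefore cannot be told apart at this position, and compound 3 joins compound 2 in showing a number where the octyl chain of compound 1 shows none. No supporting data bear on why this is so. The compounds shown leave open whether an amine or a carboxamide at the chain end would also give a number, and how a longer chain ending in carboxy would read.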